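Thiophene to Trifluoromethylphenyl on the Sulfamoyl Core

This account rests on a few compounds, and the source may have more. Where it says the series, first, only, none or still open, it means among the compounds named here.

Compound 1 `CN1CCN(c2ccc(Nc3ncc(/N=C/c4cccs4)c(NC4CCCC4)n3)cc2)CC1` gives 18900 nM in a functional assay on HCT-116 cells (Homo sapiens) for antiproliferative activity, read by MTT assay; on this read-out higher numbers stand for weaker inhibition and lower numbers for stronger inhibition. Compound 2 `CN1CCN(c2ccc(Nc3ncc(/N=C/c4ccc(C(F)(F)F)cc4)c(NC4CCCC4)n3)cc2)CC1` reaches only the limit > 100000 nM, a boundary of this assay rather than a number, as noted in the limit of > 100000 nM in this assay, at which 1 of the 3 values shown sits. Compound 3 `NS(=O)(=O)c1ccc(Nc2ncc(/N=C/c3cccs3)c(NC3CCCC3)n2)cc1` gives 13300 nM.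

The change 4-(trifluoromethyl)phenyl in place of thiophen-2-yl on a carbon with a double bond to nitrogen made the step of an at least 5.2-fold higher number from compound 1 to compound 2 (0.72 log units; beyond the scatter). The two cores differ by sulfamoyl in place of 4-methylpiperazin-1-yl on an aromatic carbon, and that difference gave a 1.4-fold lower number from compound 1 to compound 3 (0.15 log units; within the scatter), so compound 1 and compound 3 sit together. Compound 4 `NS(=O)(=O)c1ccc(Nc2ncc(/N=C/c3ccc(C(F)(F)F)cc3)c(NC3CCCC3)n2)cc1` carries the same change on the sulfamoyl core: 4-(trifluoromethyl)phenyl in place of thiophen-2-yl on a carbon with a double bond to nitrogen.

Going by the values given here, because an at least 5.2-fold higher number from compound 1 to compound 2 (0.72 log units; beyond the scatter) is the only measured example of this change, the expected step is set alongside it as a 6.8-fold higher number from compound 3 to compound 4 (0.83 log units; beyond the scatter). Compound 4 is therefore estimated at 90000 nM, between 40000 nM and 250000 nM, and a limit rather than a number is quite possible.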

Compound 4, half-maximal inhibitory concentration: > 100000 nM
Compound 4 ended at the assay's limit (the forecaster's own chance of this, stated with the estimate: 55%); middle value at least 1.1-fold (0.04 log units) from the limit.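

In this assay, putting 4-(trifluoromethyl)phenyl in place of thiophen-2-yl weakens inhibition on the sulfamoyl core as well, with an at least 7.5-fold higher number from compound 3 to compound 4 (0.87 log units; beyond the scatter), so the loss seen on the core of compound 1 carries over to this second core: the same change on two cores in this assay, an at least 5.2-fold higher number (0.72 log units; beyond the scatter) from compound 1 to compound 2 and an at least 7.5-fold higher number (0.87 log units; beyond the scatter) from compound 3 to compound 4; the limit leaves it open whether they differ Compound 4 gives > 100000 nM, which is a limit of the assay and not a number. The true size of the step therefore stays unknown on both cores, and the step between compound 2 and compound 4 cannot be read: the limit of > 100000 nM in this assay, at which 2 of the 4 values shown sit.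

The compounds shown leave open how an unsubstituted phenyl or a pyridine ring would behave in place of thiophen-2-yl. They also leave open whether the same step would appear with a carboxylic acid in place of sulfamoyl.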